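From sec-butyl to butyl on a shared core

The source may hold more compounds than are shown below. What is called first, only, known or untested is meant among the compounds shown, and "the series" means these compounds.

Compound 1 `CCC(C)NC(=C\C(=O)/C=C/c1ccc(O)c(OC)c1)/C=C/c1ccc(O)c(OC)c1` gives 22300 nM
Compound 2 `CCC(C)NC(=C\C(=O)/C=C/c1ccc(O)cc1)/C=C/c1ccc(O)cc1` gives 15600 nM

Both compounds were tested in a functional assay on HT-29 cells (Homo sapiens) for inhibition, read by sulforhodamine B assay, with a stated time of 72 h (a lower number here means a stronger inhibitor, a higher number a weaker inhibitor), and are the only measured points. Going by the values given here, compound 1 (at 22300 nM) lies within the usual scatter of compound 2 (at 15600 nM), so compound 1 stands level with its one measured neighbour.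

Compound 3 `CCCCNC(=C\C(=O)/C=C/c1ccc(O)c(OC)c1)/C=C/c1ccc(O)c(OC)c1` has not yet been measured. It keeps the core of compound 1 and differs in one place: butyl in place of sec-butyl on an amine nitrogen. Among the compounds with values here, no measured pair shows this change, so the data offer no direct guide, and no shift beyond the scatter is expected in this assay in either direction. The expected move is a 1.1-fold lower number from compound 1 to compound 3 (0.05 log units; within the scatter) (an estimate only). Compound 3 is expected to read 20000 nM (estimated range 9000 nM to 42000 nM).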

Compound 3, half-maximal inhibitory concentration: 21200 nM
Estimate against measurement, compound 3: 1.1-fold (0.03 log units) below; low and high end bracket the measured number.
By their numbers in this assay, from the lowest: compounds 2, 3 and 1 (each within the scatter of the next).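

In this assay, putting butyl in place of sec-butyl on the amine nitrogen gives a 1.1-fold lower number from compound 1 to compound 3 (0.02 log units; within the scatter) and is the only direct reading of this position among the compounds shown. On the core of compound 1, the branched and the straight chain therefore read level at this nitrogen, something the comparison of compound 1 with compound 2, which does not touch this position, could not show. Nothing available here accounts for this result.

The compounds shown leave open whether a chain of another kind on this nitrogen, such as a longer chain like octyl, a benzyl group or a chain ending in a carboxylic acid, would read differently from butyl. They also leave open whether butyl and sec-butyl would read level on the core of compound 2.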